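A few compounds are considered here, and "the series" means these few. Any claim that something is new, unique, unknown or untested is made for them only; others in the source may bear on it.

Measured compounds:
compound 1, `COc1cccc2cc(C(=O)NC3CCCCC3)c(=N)oc12`, > 70%
compound 2, `COc1cccc2cc(C(=O)N[C@@H](CO)C(=O)O)c(=O)oc12`, 24%
compound 3, `COc1cccc2cc(C(=O)NCCO)c(=O)oc12`, 7%

In an assay on HEK293 cells for displacement of a labelled ligand from adenosine receptor A2b (Homo sapiens), read by scintillation counting, with a stated time of 30 min, tested at 10 uM (a higher number here means more inhibition at the concentration tested (going by the name of the read-out), a lower number less inhibition), compound 1 reaches a limit of the assay, > 70%, a value at which (the limit of > 70% in this assay, at which 1 of the 3 values shown sits). In this assay compound 2 gives 24%, while compound 3 gives 7%. For the measured compounds named here, the single measured step, a number 17 percentage points lower from compound 2 to compound 3 (beyond the scatter), shows a modest loss when the carboxy is taken away from the hydroxylated chain.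

Compound 4, `COc1cccc2cc(C(=O)NC(CO)(CO)CO)c(=N)oc12`, has not yet been measured in this assay. It differs from compound 1 in one place: 2-hydroxy-1,1-bis(hydroxymethyl)ethyl in place of cyclohexyl on an amide-type nitrogen. Going by the values given here, no measured step swaps a cyclohexyl for a hydroxylated chain, so the step from compound 2 to compound 3 bears on the change only indirectly. What the values of compound 2 and compound 3 show is that amides carrying hydroxyl-bearing chains on the shared core give low inhibition. On that basis compound 4 is expected to lose inhibition compared with compound 1, an expected step of a number at least 45 percentage points lower from compound 1 to compound 4 (beyond the scatter). The estimate for compound 4 in this assay is 25%, expected to lie between 5% and 55%.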

Compound 4, a percentage reported as inhibition, at one concentration (the size of the read-out at that concentration, not a potency): 28%
Compound 4: the middle estimate sits 3 percentage points below what was measured; the measured number falls inside the stated range.
By their numbers in this assay, from the lowest: compound 3; then compounds 2 and 4 (each within the scatter of the next). At a limit, above all of these: compound 1.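

The swap of 2-hydroxy-1,1-bis(hydroxymethyl)ethyl for cyclohexyl on an amide-type nitrogen gives a number at least 42 percentage points lower from compound 1 to compound 4 (beyond the scatter), the first step shown in which only this group changes with cyclohexyl as the starting point, so the group on this nitrogen alone accounts for a large loss of inhibition. In this assay compound 1 gives > 70%, which is a limit of the assay. The true size of the step therefore stays unknown, because only a lower bound can be read from it: the limit of > 70% in this assay, at which 1 of the 4 values shown sits.

The compounds shown leave open whether a hexyl chain or a phenyl ring on this nitrogen would keep the inhibition seen with cyclohexyl. They also leave open how an amine or a carboxylic acid at the end of such a group would fare.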